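This account rests on a few compounds, and the source may have more. Where it says the series, first, only, none or still open, it means among the compounds named here.

Measured compounds:
- compound 1 `COc1cc(NC(C)CCCNC(=O)NNC(=O)Nc2ccc(Br)cc2)c2ncccc2c1` gives 110000 nM in a functional assay on CCRF-CEM cells (Homo sapiens) for inhibition, read by MTT assay, with a stated time of 72 h; on this read-out lower numbers stand for stronger inhibition and higher numbers for weaker inhibition
- compound 2 `COc1cc(NC(C)CCCNC(=O)NNC(=O)Nc2ccc(O)cc2)c2ncccc2c1` gives 111000 nM
- compound 3 `COc1cc(NC(C)CCCNC(=O)Nc2cccc(F)c2)c2ncccc2c1` gives 21000 nM

Compound 1 stands second highest of the three numbers; compound 2 is its nearest neighbour, a 1.0-fold higher number from compound 1 to compound 2 (0.00 log units; within the scatter), and compound 3 is furthest, a 5.2-fold lower number from compound 1 to compound 3 (0.72 log units; beyond the scatter). The change to compound 4 `COc1cc(NC(C)CCCNC(=O)Nc2cccc(C(F)(F)F)c2)c2ncccc2c1` is 3-(trifluoromethyl)phenyl in place of ((4-bromophenyl)carbamoyl)amino on an amide-type nitrogen.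

Among the measured compounds shown here, two measured steps bear on this change, since both replace the same ((4-bromophenyl)carbamoyl)amino or ((4-hydroxyphenyl)carbamoyl)amino group with an aryl group on the amide-type nitrogen: a 5.2-fold lower number from compound 1 to compound 3 (0.72 log units; beyond the scatter) and a 5.3-fold lower number from compound 2 to compound 3 (0.72 log units; beyond the scatter). Both are modest lowerings of the same size. No measured step separates a 3-fluorophenyl from a 3-(trifluoromethyl)phenyl in this series, so how compound 4 differs from compound 3 cannot be read from the numbers shown; the expectation rests on the shared removal of the ((4-bromophenyl)carbamoyl)amino group.

In this assay a modest lowering is therefore expected, a 5.5-fold lower number from compound 1 to compound 4 (0.74 log units; beyond the scatter), in the direction seen in compound 3. The estimate for compound 4 is 20000 nM, with a range from 7000 nM to 60000 nM, the width reflecting the absence of a measured aryl-to-aryl comparison.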

Compound 4, half-maximal inhibitory concentration: 19000 nM
Estimate against measurement, compound 4: 1.1-fold (0.02 log units) above; the measured number falls inside the stated range.
By their numbers in this assay, from the lowest: compounds 4 and 3 (each within the scatter of the next); then compounds 1 and 2 (each within the scatter of the next).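

In this assay, among the compounds shown here, the first direct comparison between the two aryl groups on the amide-type nitrogen gives a 1.1-fold lower number from compound 3 to compound 4 (0.04 log units; within the scatter), so trifluoromethyl in place of fluoro on the aromatic carbon does not separate these two compounds. The lowering seen with 3-fluorophenyl also appears with 3-(trifluoromethyl)phenyl, at a 5.8-fold lower number from compound 1 to compound 4 (0.76 log units; beyond the scatter) and at a 5.8-fold lower number from compound 2 to compound 4 (0.77 log units; beyond the scatter), so it holds for both aryl groups and against both departing groups, and none of the four compounds goes against it. No measurement here offers a reason for these steps.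

The aryl replacements also remove the carbamoylamino portion and change the ring substitution, so these compounds do not show whether the lowering follows the loss of that portion or the new substitution on the ring. Also open, on these data alone, is how this assay responds to an amine or a carboxylic acid on the phenyl ring, or to a longer chain in place of the aryl group on the amide-type nitrogen.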